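The source may report more compounds than this note shows. Statements on the series, on what has been measured and on what is new or still open speak of the compounds shown alone.

Measured so far in a functional assay on Caco-2 cells (Homo sapiens) for inhibition, read by sulforhodamine B assay, with a stated time of 72 h (a lower number here means a stronger inhibitor, a higher number a weaker inhibitor), are these values:

- compound 1 `CCCNC(=C\C(=O)/C=C/c1ccc(O)c(OC)c1)/C=C/c1ccc(O)c(OC)c1` gives 22000 nM
- compound 2 `COc1cc(/C=C/C(=O)/C=C(/C=C/c2ccc(OC(C)=O)c(OC)c2)NCC(C)C)ccc1OC(C)=O` gives > 25000 nM as a limit of the assay and not a number
- compound 3 `CC(=O)Oc1ccc(/C=C/C(=O)/C=C(/C=C/c2ccc(OC(C)=O)cc2)NCC(C)C)cc1` gives > 25000 nM as a limit of the assay and not a number

Going by the values given here, compound 1 is the only compound here with a number, and the remaining readings make up the limit of > 25000 nM in this assay, at which 2 of the 3 values shown sit, in this small set. Among the compounds with values here, no step between two measured compounds that differ in one place is available, so the series gives no direct measure of what a single change does.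

Next in line is compound 4 `COc1cc(/C=C/C(=O)/C=C(/C=C/c2ccc(O)c(OC)c2)NCC(C)C)ccc1O`, which differs from compound 1 by methyl in place of hydrogen on a saturated chain carbon bound to two saturated chain carbons and so reads as propylamino to isobutylamino. The change is methyl in place of hydrogen on a saturated chain carbon bound to two saturated chain carbons.

With compound 1 at 22000 nM as the only numerical anchor, no shift beyond the usual scatter is expected in either direction in this assay. The expected step of a 1.2-fold lower number from compound 1 to compound 4 (0.06 log units; within the scatter) is therefore small and has no firm direction. A reading reported only as a limit remains possible. For compound 4 the estimated value is 19000 nM with an expected range of 8000 nM to 30000 nM in the half-maximal inhibitory concentration.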

Compound 4, half-maximal inhibitory concentration: > 25000 nM
Compound 4 gave a limit, no number (the forecaster's own chance of this, stated with the estimate: 30%); middle value at least 1.3-fold (0.11 log units) away from the limit.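

In this assay compound 4 gives > 25000 nM, which is a limit of the assay and not a number. Going from propylamino to isobutylamino, with methyl in place of hydrogen on a saturated chain carbon bound to two saturated chain carbons, gives an at least 1.1-fold higher number from compound 1 to compound 4 (0.05 log units; that floor lies within the scatter), so this change now has a first reading, but only as a floor that shows no shift beyond the usual scatter. The series still holds a single number, that of compound 1, and compound 4 joins the other readings at the limit: the limit of > 25000 nM in this assay, at which 3 of the 4 values shown sit.

The compounds shown leave open how far past the limit compound 4 lies, and so whether the true size of this step exceeds the scatter. They also leave open how a shorter chain such as ethylamino, a longer chain such as butylamino, or a cyclic amine such as morpholine would read in this assay in place of the propylamino group of compound 1.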